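Propyl in Place of Methyl on a Weakly Active Core

The compounds below may be only part of what the source reports. "The series", "measured", "known", "first", "only" and "open" are said of these compounds alone.

Compound 1, `CCCc1nc(C)c2c(C)nn(C)c(=O)n12`: > 48000 nM in this assay
Compound 2, `Cc1nc(C)n2c(=O)n(C)ncc12`: > 48000 nM in this assay

The account follows the step from compound 2 to compound 3. In a functional assay for inhibition, with Homo sapiens as the target (on this read-out lower numbers stand for stronger inhibition and higher numbers for weaker inhibition), compound 2 gives > 48000 nM, which is a limit of the assay and not a measured number. In the same assay compound 1 gives > 48000 nM, again a limit and not a number. Both values therefore sit at the limit of > 48000 nM in this assay, at which 2 of the 2 values shown sit, so nothing in the shown data separates compound 1 from compound 2, and no measured step between them is available.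

Compound 3, `CCCc1nc(C)c2cnn(C)c(=O)n12`, differs from compound 2 by ethyl in place of hydrogen on a saturated chain carbon bound to an aromatic carbon. The pair shown gives no step from which a size could be read, so the expectation rests only on where compound 2 stands. Since compound 2 sits at the limit, any gain from compound 2 to compound 3 would have to be large before a number appears; the estimate for this step is a step that the limit leaves unreadable from compound 2 to compound 3, which is taken to be no change beyond the scatter. Compound 3 is therefore expected to give 60000 nM in this assay, with a range from 20000 nM to 200000 nM, most likely reported again only as a limit.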

Compound 3, half-maximal inhibitory concentration: 20000 nM
Beside the measured number, compound 3's estimate is 3.0-fold (0.48 log units) above it; measured number inside the range.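

Ethyl in place of hydrogen on a saturated chain carbon bound to an aromatic carbon, which is the same difference as methyl to propyl, gives an at least 2.4-fold lower number from compound 2 to compound 3 (0.38 log units; beyond the scatter) in this assay and so shows that a change at this chain position can bring the read-out off the limit to a real number. Hydrogen in place of methyl on an aromatic carbon gives an at least 2.4-fold lower number from compound 1 to compound 3 (0.38 log units; beyond the scatter) and shows that the propyl chain is not enough by itself, since compound 1 carries it as well. Among these three compounds a number appears only where propyl and that aromatic hydrogen occur together, while the other two remain at a limit: the limit of > 48000 nM in this assay, at which 2 of the 3 values shown sit.

Going by these compounds, the true size of both steps stays open, for each starts from a limit and gives only a lower bound, and the activity of compound 3 remains weak in absolute terms. On these data alone, whether a longer chain such as butyl, or an amine at the end of the propyl chain, would lower the number further is also open, as is whether chlorine on that aromatic carbon would behave like methyl or like hydrogen.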